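This account rests on a few compounds, and the source may have more. Where it says the series, first, only, none or still open, it means among the compounds named here.

Compound 1 `CCN1C(=O)N(CC)C2C1NC(=S)N2/N=C/C=C/c1ccccc1` serves as the starting point of this small series. In a functional assay on A549 cells (Homo sapiens) for inhibition, read by MTT assay, with a stated time of 72 h (a higher number here means a weaker inhibitor, a lower number a stronger inhibitor), compound 1 gives 6530 nM. Compound 2 `CCN1C(=O)N(CC)C2C1NC(=S)N2/N=C/C=C/c1ccccc1[N+](=O)[O-]` carries a single change relative to it, (nitro in place of hydrogen on an aromatic carbon). In this assay compound 2 reaches only a limit, > 100000 nM, and not a number; (the limit of > 100000 nM in this assay, at which 1 of the 3 values shown sits). The change therefore produced an at least 15-fold higher number from compound 1 to compound 2 (1.18 log units; beyond the scatter).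

Compound 3 `CCN1C(=O)N(CC)C2C1NC(=O)N2/N=C/C=C/c1ccccc1` shares the general build of compound 1 but differs from it in a way that is not broken down here. In this assay compound 3 gives 44300 nM, a higher number than compound 1.

Compound 4 `CCN1C(=O)N(CC)C2C1NC(=O)N2/N=C/C=C/c1ccccc1[N+](=O)[O-]` has not yet been measured. It stands to compound 3 as compound 2 stands to compound 1, with nitro in place of hydrogen on an aromatic carbon, and the surroundings of the change are the same in both pairs. Compound 4 is accordingly expected to show a 6.8-fold higher number from compound 3 to compound 4 (0.83 log units; beyond the scatter). The number for compound 4 is estimated to be 300000 nM, between 60000 nM and 1500000 nM, an expectation that rests on the step of an at least 15-fold higher number from compound 1 to compound 2 (1.18 log units; beyond the scatter) applied to the higher starting number of compound 3.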

Compound 4, half-maximal inhibitory concentration: > 100000 nM
Compound 4: a limit, no number; the forecaster's own chance of this, stated with the estimate: 80%; the middle value is on the limit's open side.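

With nitro in place of hydrogen on the aromatic carbon, compound 4 again gives a limit and not a number, and the step reads an at least 2.2-fold higher number from compound 3 to compound 4 (0.35 log units; beyond the scatter). On both cores shown, the change therefore moves the result in the same direction, towards a higher number and so a weaker inhibitor, and both nitro compounds end at the same limit: the limit of > 100000 nM in this assay, at which 2 of the 4 values shown sit. This supports carrying the direction of the change from the core of compound 1 to the core of compound 3, but it does not show that the size of the step carries over, because neither step has a measured endpoint: the same change on two cores in this assay, an at least 15-fold higher number (1.18 log units; beyond the scatter) from compound 1 to compound 2 and an at least 2.2-fold higher number (0.35 log units; beyond the scatter) from compound 3 to compound 4; the limit leaves it open whether they differ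

The compounds shown leave open how large either step really is, since no nitro compound has a number in this assay. They also leave open whether an amine or a carboxylic acid on the same aromatic carbon, in place of the nitro group, would give a number on either core.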